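A few compounds are considered here, and "the series" means these few. Any claim that something is new, unique, unknown or untested is made for them only; others in the source may bear on it.

Measured so far in a functional assay, read by spectrophotometry, with a stated time of 30 min, tested at 100 ug/mL; a lower number here means a weaker effect, a higher number a stronger effect of the compound at the concentration tested:
- compound 1 `CCN1CCN(CC(=O)Nc2nc3ccccc3[nH]2)CC1`: compound 1 gives 45.7%
- compound 2 `O=C(CN1CCN(c2ncccn2)CC1)Nc1nc2ccccc2[nH]1`: compound 2 gives 46.5%
- compound 3 `COc1ccc(N2CCN(CC(=O)Nc3nc4ccccc4[nH]3)CC2)cc1`: compound 3 gives 38.9%

All three share one core and differ only in the group on the ring nitrogen. The three numbers sit close together: a number 0.8 percentage points higher from compound 1 to compound 2 (within the scatter), a number 6.8 percentage points lower from compound 1 to compound 3 (within the scatter), a number 7.6 percentage points lower from compound 2 to compound 3 (within the scatter). Compound 3 has the smallest of the three numbers, but both of its gaps lie within the scatter, so the three compounds cannot be told apart in this assay.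

Next is compound 4 `O=C(CN1CCN(c2ccc([N+](=O)[O-])cc2)CC1)Nc1nc2ccccc2[nH]1`. The change from compound 3 is nitro in place of methoxy on an aromatic carbon. Going by the values given here, no measured step alters a substituent on the phenyl ring itself; the nearest comparisons are the exchanges of the whole group on the ring nitrogen, which are all within the scatter. Nothing in the measured set therefore points to a shift beyond the scatter, and the expected step is a number 1.1 percentage points higher from compound 3 to compound 4 (within the scatter). Compound 4 is estimated at 40% in this assay, with a range from 27% to 53%.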

Compound 4, a percentage reported as activity, at one concentration (the size of the read-out at that concentration, not a potency): 51.7%
Compound 4: the middle estimate sits 11.7 percentage points below what was measured, and the stated range covers the measured number.
By their numbers in this assay, from the lowest: compounds 3, 1, 2 and 4 (each within the scatter of the next, the first and the last beyond it).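

In this assay, going by these compounds alone, the change on the aromatic carbon para to a large group gives the first step beyond the scatter (a number 12.8 percentage points higher from compound 3 to compound 4 (beyond the scatter)), so a substituent on this phenyl ring can move the read-out even though exchanges of the whole group on the ring nitrogen among compounds 1, 2 and 3 did not. The gain separates compound 4 only from compound 3, as it stays within the scatter of the other two (a number 5.2 percentage points higher from compound 2 to compound 4 (within the scatter); a number 6 percentage points higher from compound 1 to compound 4 (within the scatter)). No measurement at hand explains the step.

With one pair of substituents, the step cannot be assigned to the arrival of nitro rather than the departure of methoxy. The unsubstituted phenyl, or a nitrile or an amine at the same carbon, would help to separate the two readings.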